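Ethylamino to piperazin-1-yl in the series

The source may hold more compounds than are shown below. What is called first, only, known or untested is meant among the compounds shown, and "the series" means these compounds.

Measured so far in a functional assay on NB1 cells (Homo sapiens) for cytotoxicity, read by MTT assay, with a stated time of 3 days; a higher number here means a weaker inhibitor, a lower number a stronger inhibitor
Compound 1 `CCNc1nc(SCc2nc3ccccc3[nH]2)nc(-c2ccccc2)c1C#N` gives 2.63 nM
Compound 2 `N#Cc1c(Nc2nccs2)nc(SCc2nc3ccccc3[nH]2)nc1-c1ccccc1` gives 3.2 nM
Compound 3 `N#Cc1c(NC(N)=O)nc(SCc2nc3ccccc3[nH]2)nc1-c1ccccc1` gives 7.35 nM

Compound 1 shares the low end of the three numbers with its nearest neighbour, the step being a 1.2-fold higher number from compound 1 to compound 2 (0.09 log units; within the scatter). The furthest step from it is a 2.8-fold higher number from compound 1 to compound 3 (0.45 log units; beyond the scatter).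

The next compound is compound 4 `N#Cc1c(-c2ccccc2)nc(SCc2nc3ccccc3[nH]2)nc1N1CCNCC1`, which has piperazin-1-yl in place of ethylamino on an aromatic carbon. The measured steps bear on this only indirectly. Each one changes the group on the nitrogen and keeps that nitrogen, whereas here the whole ethylamino leaves. Those steps stayed small, and the largest is a 2.8-fold higher number from compound 1 to compound 3 (0.45 log units; beyond the scatter). Going by the values given here, no measured compound carries a ring of the entering kind, so the direction is uncertain. A modest move to a higher number is expected in this assay, with no large loss anticipated. The estimated step is a 2.3-fold higher number from compound 1 to compound 4 (0.36 log units; beyond the scatter). Compound 4 is estimated at 6 nM with 1.8 nM to 20 nM as the expected range.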

Compound 4, half-maximal inhibitory concentration: 6.75 nM
Compound 4: middle estimate off by 1.1-fold (0.05 log units), on the low side; the measured number falls inside the stated range.
By their numbers in this assay, from the lowest: compounds 1 and 2 (each within the scatter of the next); then compounds 4 and 3 (each within the scatter of the next).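

In this assay, replacing the whole ethylamino with piperazin-1-yl, so that the attached nitrogen becomes part of a six-membered non-aromatic ring, gives only a modest rise in the number (a 2.6-fold higher number from compound 1 to compound 4 (0.41 log units; beyond the scatter)). Set against the ureido group the ring makes no readable difference (a 1.1-fold lower number from compound 3 to compound 4 (0.04 log units; within the scatter)), while against (1,3-thiazol-2-yl)amino the rise is again modest (a 2.1-fold higher number from compound 2 to compound 4 (0.32 log units; beyond the scatter)), so this position accepts a ring directly on the aromatic carbon and the number stays in the same low range. Nothing available explains these steps.

Still open, going by these compounds, is whether the second ring nitrogen of piperazin-1-yl matters, which a morpholin-4-yl or 4-methylpiperazin-1-yl group at this carbon would test. The compounds shown also leave open how a longer chain such as butylamino compares with ethylamino.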